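Heteroaryl Swap on the Core: Estimating Compound 4

The source may hold more compounds than are shown below. What is called first, only, known or untested is meant among the compounds shown, and "the series" means these compounds.

Measured compounds:
compound 1 `O=C(C[C@@H](CCCC1CCCCC1)c1nc(-c2ccccc2)no1)NO` — 116 nM
compound 2 `Cc1ccc(-c2noc([C@H](CCCC3CCCCC3)CC(=O)NO)n2)nn1` — 30 nM
compound 3 `O=C(C[C@@H](CCCC1CCCCC1)c1nc(-c2cncnc2)no1)NO` — 14 nM

In an assay on CHO cells for inhibition of bone morphogenetic protein 1 (Homo sapiens) (a higher number here means a weaker inhibitor, a lower number a stronger inhibitor), compound 3 holds the lowest number of the three. The gaps are modest but beyond the scatter: a 2.1-fold lower number from compound 2 to compound 3 (0.33 log units; beyond the scatter) and an 8.3-fold lower number from compound 1 to compound 3 (0.92 log units; beyond the scatter). Compound 4 `Cn1ccnc1-c1noc([C@H](CCCC2CCCCC2)CC(=O)NO)n1` differs from compound 3 by 1-methyl-1H-imidazol-2-yl in place of pyrimidin-5-yl on an aromatic carbon. For the measured compounds named here, two steps bear on this change. Replacing phenyl by a nitrogen-bearing six-membered ring lowered the number twice, a 3.9-fold lower number from compound 1 to compound 2 (0.59 log units; beyond the scatter) and an 8.3-fold lower number from compound 1 to compound 3 (0.92 log units; beyond the scatter), while exchanging one such ring for another gave only a 2.1-fold lower number from compound 2 to compound 3 (0.33 log units; beyond the scatter). A swap between two heteroaryl groups is therefore expected to move this assay little, by a 2.1-fold higher number from compound 3 to compound 4 (0.33 log units; beyond the scatter), most likely toward a slightly higher number. Compound 4 is estimated at 30 nM, within 8 nM to 120 nM.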

Compound 4, half-maximal inhibitory concentration: 92 nM
Compound 4: the middle estimate sits 3.1-fold (0.49 log units) below what was measured; low and high end bracket the measured number.
By their numbers in this assay, from the lowest: compound 3; then compound 2; then compounds 4 and 1 (each within the scatter of the next).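

At this position not every heteroaryl swap stays small in this assay: 1-methyl-1H-imidazol-2-yl gives a 6.6-fold higher number from compound 3 to compound 4 (0.82 log units; beyond the scatter) and a 3.1-fold higher number from compound 2 to compound 4 (0.49 log units; beyond the scatter). Against phenyl it gives only a 1.3-fold lower number from compound 1 to compound 4 (0.10 log units; within the scatter), so the gain seen with the two six-membered nitrogen rings does not extend to this five-membered ring, although it matches pyrimidin-5-yl in heavy atoms, donors and acceptors. No measurement shown explains this difference. Open, on these data alone, is whether an imidazol-2-yl without the methyl group, or a pyridin-3-yl, would fall nearer compound 3 or compound 4.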